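A few compounds are considered here, and "the series" means these few. Any claim that something is new, unique, unknown or untested is made for them only; others in the source may bear on it.

Compounds measured so far:
- compound 1 `COc1cc(/C=C/C(=O)/C=C/c2nc3c(C)cccc3n2C)ccc1O`: 3500 nM
- compound 2 `COc1ccc(/C=C/C(=O)/C=C/c2nc3cc(C)ccc3n2C)cc1O`: 3600 nM
- compound 3 `COc1ccc(/C=C/C(=O)/C=C/c2nc3c(C)c(C)ccc3n2C)cc1O`: 3500 nM

All three values come from a functional assay on MCF7 cells (Homo sapiens) for cytotoxicity, read by MTT assay, with a stated time of 48 h (a lower number here means a stronger inhibitor, a higher number a weaker inhibitor), and they lie within the scatter of one another. Compound 2, at 3600 nM, therefore stands level with the other two, and no order can be read among them.

The next compound is compound 4 `COc1ccc(/C=C/C(=O)/C=C/c2nc3cc(Cl)ccc3n2C)cc1O`, which has chloro in place of methyl on an aromatic carbon of compound 2: chloro in place of methyl on an aromatic carbon.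

For the measured compounds named here, only one measured step bears on this change: a 1.0-fold lower number from compound 2 to compound 3 (0.01 log units; within the scatter). That step adds a methyl in place of hydrogen on an aromatic carbon, so it is only indirect evidence for a swap of methyl for chloro. It shows that one added methyl on this part of the shared core left the value within the scatter. Going by the values given here, no measured compound carries chloro, so the size of this particular swap remains untested. The evidence offers no direction for a change in this assay, and no step beyond the scatter is expected.

The expected result is a 1.1-fold lower number from compound 2 to compound 4 (0.05 log units; within the scatter). For compound 4 the estimated value is 3200 nM, with an expected range from 1500 nM to 6500 nM.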

Compound 4, half-maximal inhibitory concentration: 3500 nM
Estimate against measurement, compound 4: 1.1-fold (0.04 log units) below, and the stated range covers the measured number.
By their numbers in this assay, from the lowest: compounds 1, 3, 4 and 2 (each within the scatter of the next).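

For the compounds shown here, compound 4 gives the first direct reading of a swap at this aromatic carbon in this assay: a 1.0-fold lower number from compound 2 to compound 4 (0.01 log units; within the scatter). The earlier step, a 1.0-fold lower number from compound 2 to compound 3 (0.01 log units; within the scatter), only added a methyl in place of hydrogen and left the methyl of compound 2 in place, whereas here that methyl itself gives way to chloro and compound 2 and compound 4 stand level. Within this pair, then, the value does not distinguish methyl from chloro at this carbon, and no evidence at hand offers an explanation for that.

Both groups at this carbon count a single heavy atom with no hydrogen-bond donor or acceptor, so the shown compounds leave open whether a larger or hydrogen-bonding group there, such as an amine, a carboxylic acid or a propyl chain, would stay level with compound 2. From the compounds shown here alone, it also remains open whether any change on this six-membered aromatic ring can separate compounds in this assay, given that all the values so far lie within the scatter of one another.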